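Amine swap at the chain end of the core

The source may hold more compounds than are shown below. What is called first, only, known or untested is meant among the compounds shown, and "the series" means these compounds.

Measured so far:
- compound 1, `COc1cc2c(Oc3ccc(NC(=O)c4cc(-c5ccccc5)ccn4)cc3F)ccnc2cc1OCCCN1CCN(C)CC1` — in a functional assay on U-87MG ATCC cells (Homo sapiens) for cytotoxicity, read by MTT assay, with a stated time of 72 h (a higher number here means a weaker inhibitor, a lower number a stronger inhibitor), compound 1 gives 1010 nM
- compound 2, `COc1cc2c(Oc3ccc(NC(=O)c4cc(-c5ccc(F)cc5)ccn4)cc3F)ccnc2cc1OCCCN1CCN(C)CC1` — in this assay compound 2 gives "not determined" (no result reported)
- compound 3, `COc1ccc(-c2ccnc(C(=O)Nc3ccc(Oc4ccnc5cc(OCCCN6CCN(C)CC6)c(OC)cc45)c(F)c3)c2)c(OC)c1` — in this assay compound 3 gives "not determined" (no result reported)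

For the measured compounds named here, compound 1 is the only member of the series with a number; compounds 2 and 3, which carry a fluorine or two methoxy groups on the pendant phenyl, have no result reported, so nothing can be said of their standing relative to compound 1. Compound 1 therefore sets the reference point on its own.

Compound 4, `COc1cc2c(Oc3ccc(NC(=O)c4cc(-c5ccccc5)ccn4)cc3F)ccnc2cc1OCCCN1CCCCC1`, keeps the whole core of compound 1 and changes only the terminal amine of the side chain: piperidin-1-yl in place of 4-methylpiperazin-1-yl on a saturated chain carbon, three bonds along the chain from an oxygen on an aromatic ring. Going by the values given here, no measured pair shows what such a swap at the chain end does. Without a comparable step to lean on, the step of a 1.2-fold higher number from compound 1 to compound 4 (0.07 log units; within the scatter) is expected to stay within the usual scatter, with no clear direction. Compound 4 is accordingly estimated at 1200 nM, with a range from 400 nM to 3500 nM.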

Compound 4, half-maximal inhibitory concentration: 790 nM
Beside the measured number, compound 4's estimate is 1.5-fold (0.18 log units) above it; the measured number falls inside the stated range.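

In this assay, for the compounds shown here, piperidin-1-yl in place of 4-methylpiperazin-1-yl on the saturated chain carbon gives a 1.3-fold lower number from compound 1 to compound 4 (0.11 log units; within the scatter), the first measured pair at this position. The assay does not separate the two terminal rings, one with 2 hetero atoms and one with 1 hetero atom, so in this single pair the chain end accepts the swap with no readable effect on the number. No available supporting data bear on this result.

Still open, as far as these compounds go, is whether a morpholin-4-yl or dimethylamino group at the chain end, or a longer chain carrying piperidin-1-yl, would also stay within the scatter of compound 1. Also open, from the compounds shown here alone, is whether the swap reads the same when the pendant phenyl carries a substituent such as a nitrile.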